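The source may hold more compounds than are shown below. What is called first, only, known or untested is meant among the compounds shown, and "the series" means these compounds.

Three compounds that share one core differ only in the group on the carbonyl carbon. Compound 1 `O=C(/C=C/c1ccc2c(c1)B(O)OC2)c1ccco1` carries a furan-2-yl there; in a functional assay on MDA-MB-231 cells (Homo sapiens) for cytotoxicity, read by MTT assay, with a stated time of 48 h (a higher number here means a weaker inhibitor, a lower number a stronger inhibitor), compound 1 gives 7300 nM. Compound 2 `O=C(/C=C/c1ccc2c(c1)B(O)OC2)c1ccc(Cl)cc1` carries a 4-chlorophenyl, and in this assay compound 2 gives 7900 nM. Compound 3 `Cc1ccc(C(=O)/C=C/c2ccc3c(c2)B(O)OC3)cc1` carries a 4-methylphenyl, and in this assay compound 3 gives 6500 nM. Among these three numbers compound 1 stands second highest, and the steps around it, a 1.1-fold higher number from compound 1 to compound 2 (0.03 log units; within the scatter) and a 1.1-fold lower number from compound 1 to compound 3 (0.05 log units; within the scatter), both lie within the scatter, as does a 1.2-fold lower number from compound 2 to compound 3 (0.08 log units; within the scatter).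

Compound 4 `O=C(/C=C/c1ccc2c(c1)B(O)OC2)c1ccc(O)cc1` is not yet measured. It differs from compound 1 in one place: 4-hydroxyphenyl in place of furan-2-yl on a carbonyl carbon. Within the data shown here, the steps that bear on this change are the two exchanges of the furan-2-yl of compound 1 for a six-membered carbon-only ring, a 1.1-fold higher number from compound 1 to compound 2 (0.03 log units; within the scatter) and a 1.1-fold lower number from compound 1 to compound 3 (0.05 log units; within the scatter), each within the scatter; the exchange of chloro for methyl, a 1.2-fold lower number from compound 2 to compound 3 (0.08 log units; within the scatter), was also within the scatter. Among the measured compounds shown here, the 4-hydroxyphenyl itself appears in no measured compound. On this basis the expected step in this assay is none beyond the scatter, namely a 1.0-fold lower number from compound 1 to compound 4 (0.02 log units; within the scatter). Compound 4 is therefore estimated to give 7000 nM in this assay, with a range from 3500 nM to 14000 nM.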

Compound 4, half-maximal inhibitory concentration: 25600 nM
Estimate against measurement, compound 4: 3.7-fold (0.56 log units) below; the whole stated range lies below it.
By their numbers in this assay, from the lowest: compounds 3, 1 and 2 (each within the scatter of the next); then compound 4.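

The group on the carbonyl carbon had seemed indifferent in this assay across furan-2-yl, 4-chlorophenyl and 4-methylphenyl, but the 4-hydroxyphenyl separates from them with a 3.5-fold higher number from compound 1 to compound 4 (0.54 log units; beyond the scatter) and so shows that this position does respond to some changes. The same holds for the single aromatic carbon that carries the exchanged group, where hydroxy in place of methyl gives a 3.9-fold higher number from compound 3 to compound 4 (0.60 log units; beyond the scatter) and hydroxy in place of chloro gives a 3.2-fold higher number from compound 2 to compound 4 (0.51 log units; beyond the scatter) while the earlier exchange of chloro for methyl gave only a 1.2-fold lower number from compound 2 to compound 3 (0.08 log units; within the scatter) and stayed within the scatter. The entering 4-hydroxyphenyl carries a hydrogen-bond donor that the furan-2-yl does not, but nothing measured here connects that count to the higher number or otherwise accounts for it.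

The compounds shown leave open whether the higher number belongs to the hydroxy itself or would also come with a methoxy, an amine or a carboxylic acid on the same aromatic carbon. They also leave open whether a hydroxy on a five-membered ring such as the furan-2-yl would give a similar step.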